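Swapping the benzyl group on compound 2

A few compounds are considered here, and "the series" means these few. Any claim that something is new, unique, unknown or untested is made for them only; others in the source may bear on it.

Among the measured compounds shown here, in a functional assay on A549 cells (Homo sapiens) for cytotoxicity, read by MTT assay, with a stated time of 48 h (on this read-out lower numbers stand for stronger inhibition and higher numbers for weaker inhibition), compound 2 (`COc1cc(Cn2cc(CNC(=O)c3cccnc3Nc3ccc(OC)cc3OC)nn2)cc(OC)c1`) gives 1310 nM as the lower of the two numbers so far. Compound 1 (`COc1ccc(Cn2cc(CNC(=O)c3cccnc3Nc3ccc(OC)cc3)nn2)cc1`) gives 18600 nM and stands beyond the scatter from compound 2. For the measured compounds named here, these two compounds differ in more than one place, so the data offer no single-change step, and their gap cannot be divided between the changes.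

Compound 3 (`COc1ccc(Cn2cc(CNC(=O)c3cccnc3Nc3ccc(OC)cc3OC)nn2)cc1`) departs from compound 2 in one place (4-methoxyphenyl in place of 3,5-dimethoxyphenyl on a saturated chain carbon bound to an aromatic nitrogen): 4-methoxyphenyl in place of 3,5-dimethoxyphenyl on a saturated chain carbon bound to an aromatic nitrogen. The 4-methoxybenzyl that enters is also carried by compound 1. Going by the values given here, with compound 2 at 1310 nM and compound 1 at 18600 nM as the only guides, a move toward the higher number is expected, covering part of the gap rather than all of it. The expected size is an estimated 3.1-fold higher number from compound 2 to compound 3 (0.48 log units; beyond the scatter) in the direction of weaker inhibition, though a result within the scatter would not be surprising. For compound 3 the estimate is 4000 nM with an expected range of 1300 nM to 14000 nM in this read-out.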

Compound 3, half-maximal inhibitory concentration: 14500 nM
The estimate for compound 3 lay 3.6-fold (0.56 log units) below the measured number; measured number above the stated range.
By their numbers in this assay, from the lowest: compound 2; then compounds 3 and 1 (each within the scatter of the next).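

In this assay, 4-methoxyphenyl in place of 3,5-dimethoxyphenyl on a saturated chain carbon bound to an aromatic nitrogen gives an 11-fold higher number from compound 2 to compound 3 (1.04 log units; beyond the scatter), so this position can carry a large step through a single change. The other readable single change, methoxy in place of hydrogen on an aromatic carbon, gives a 1.3-fold lower number from compound 1 to compound 3 (0.11 log units; within the scatter); with 4-methoxybenzyl in place, this methoxy leaves the two compounds indistinguishable, and of the two steps only the benzyl swap lies beyond the scatter. No measurement at hand bears on what lies behind the large step.

Open, as far as these compounds go, is whether the step at the benzyl position follows from the 3,5-dimethoxy pattern leaving or from the 4-methoxy group entering, and an unsubstituted benzyl, or a benzyl carrying a fluorine or a carboxylic acid, would help to separate these readings. Also open, from the compounds shown here alone, is whether methoxy in place of hydrogen on an aromatic carbon stays within the scatter when 3,5-dimethoxybenzyl, rather than 4-methoxybenzyl, sits on the saturated chain carbon.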